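Aryl Swap on the Amine Nitrogen and Cell Toxicity

The source may report more compounds than this note shows. Statements on the series, on what has been measured and on what is new or still open speak of the compounds shown alone.

Compound 2 `O=C(O)c1ccc(-c2nn(-c3ccc(C(F)(F)F)cc3)cc2CNc2ccc(Cl)c(Cl)c2)cc1` in a toxicity assay on HEK293 cells (Homo sapiens) for cytotoxicity, read by resazurin assay, with a stated time of 24 h (on this read-out higher numbers stand for weaker inhibition and lower numbers for stronger inhibition), gives > 12 ug/mL, which is a limit of the assay rather than a number. Compound 1 `Cc1ccc(NCc2cn(-c3ccc(C(F)(F)F)cc3)nc2-c2ccc(C(=O)O)cc2)cc1Cl` likewise gives > 12 ug/mL, also a limit. The step that the two limits leave unreadable from compound 1 to compound 2 therefore cannot be read. Compound 3 `Cc1cc(NCc2cn(-c3ccc(C(F)(F)F)cc3)nc2-c2ccc(C(=O)O)cc2)ccc1Br` differs from compound 2 by 4-bromo-3-methylphenyl in place of 3,4-dichlorophenyl on an amine nitrogen. Among the compounds with values here, both measured values sit at the same limit (the limit of > 12 ug/mL in this assay, at which 2 of the 2 values shown sit), so no measured step speaks to this change, and no move beyond the scatter is expected. Compound 3 is expected at 20 ug/mL, within a range from 8 ug/mL to 60 ug/mL. The step that the limit leaves unreadable from compound 2 to compound 3 is expected to stay within the scatter.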

Compound 3, half-maximal inhibitory concentration: > 12 ug/mL
Compound 3 ended at the assay's limit; the forecaster's own chance of this, stated with the estimate: 80%; the middle value lies beyond the limit too.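

In this assay compound 3 gives > 12 ug/mL, which is a limit of the assay and not a number. Within the data shown here, no step among compound 1, compound 2 and compound 3 can be read: the limit of > 12 ug/mL in this assay, at which 3 of the 3 values shown sit. Going by these compounds, whether the aryl group on the amine nitrogen makes any difference in this assay stays open.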